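Dihydroxy-dichloro core amides: aryl tail variation

This account rests on a few compounds, and the source may have more. Where it says the series, first, only, none or still open, it means among the compounds named here.

Measured so far:
compound 1, `O=C(CCCc1ccc(Cl)cc1)N1CCc2c(Cl)c(O)c(O)c(Cl)c2C1`, 80%
compound 2, `O=C(CCCc1ccc(C(F)(F)F)cn1)N1CCc2c(Cl)c(O)c(O)c(Cl)c2C1`, 72%

Compound 1 and compound 2 share the same core and differ only in the aryl group at the end of the saturated chain. In a functional assay (Homo sapiens), tested at 1 uM (on this read-out higher numbers stand for a weaker effect at the one concentration tested and lower numbers for a stronger effect), compound 1 gives 80%. Compound 2 carries a pyridine ring with a trifluoromethyl group in place of the chlorophenyl of compound 1. In this assay compound 2 gives 72%; the two numbers lie within the usual scatter of each other, so no order between them can be stated on these data.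

Compound 3, `N#Cc1ccc(CCCC(=O)N2CCc3c(Cl)c(O)c(O)c(Cl)c3C2)nc1`, is not yet measured. It differs from compound 1 as follows: 5-cyanopyridin-2-yl in place of 4-chlorophenyl on a saturated chain carbon, three bonds along the chain from a carbonyl carbon. Among the compounds with values here, only two numbers exist so far and both sit close together, so there is nothing to suggest a large effect of swapping this aryl group. The estimate for compound 3 in this assay is 72%, with a range from 55% to 88%. The expected step of a number 8 percentage points lower from compound 1 to compound 3 (within the scatter) is small and stays within the scatter.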

Compound 3, a percentage reported as activity, at one concentration (the size of the read-out at that concentration, not a potency): 86%
The estimate for compound 3 lay 14 percentage points below the measured number; the measured number falls inside the stated range.
By their numbers in this assay, from the lowest: compounds 2, 1 and 3 (each within the scatter of the next, the first and the last beyond it).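

In this assay, 5-cyanopyridin-2-yl in place of 4-chlorophenyl on a saturated chain carbon, three bonds along the chain from a carbonyl carbon, gives a number 6 percentage points higher from compound 1 to compound 3 (within the scatter) and so does not separate the two compounds, even though the entering group differs in ring type and hydrogen-bond acceptor count. The series' first readable step comes from a smaller edit, with the pyridine ring and chain kept and only the ring substituent changed: cyano in place of trifluoromethyl on an aromatic carbon gives a number 14 percentage points higher from compound 2 to compound 3 (beyond the scatter), a modest step toward a weaker effect at the one concentration tested. Nothing available explains why these two substituents differ in this read-out.

Still open, as far as these compounds go, is whether other substituents at that aromatic carbon, such as an amine or a carboxylic acid, would move the number beyond the scatter in either direction from compound 2, and whether a longer chain would change it. Also open, from the compounds shown here alone, is what the ring nitrogen contributes alone, which would take a phenyl ring carrying the same cyano group on the shared core.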